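Smaller amide on the carbonyl: compound 2 to compound 4

A few compounds are considered here, and "the series" means these few. Any claim that something is new, unique, unknown or untested is made for them only; others in the source may bear on it.

The series is read in an assay on the whole organism (plasma, strain Sprague-Dawley) for inhibition of Dipeptidyl peptidase 4 (Rattus norvegicus), with a stated time of 6 h, at a dose of 1 mg/kg by the oral route; on this read-out lower numbers stand for less inhibition and higher numbers for more inhibition at the one dose given (going by the name of the read-out). Compound 1 `CCN(C)C(=O)[C@H]1C[C@@H](C(=O)N2CCC[C@H]2C#N)N[C@H]1C` gives 92% in this assay. Compound 2 `C[C@@H]1N[C@H](C(=O)N2CCC[C@H]2C#N)C[C@@H]1C(=O)N1CCSCC1` gives 92%. Compound 3 `N#C[C@@H]1CCCN1C(=O)[C@@H]1C[C@H](C(=O)N2CCCCC2)CN1` gives 84%. Among the measured compounds shown here, the one step between neighbours, no change at the digits printed from compound 1 to compound 2 (within the scatter), is within the scatter. Compound 2 therefore stands level with compound 1 at the digits shown, and its gap to compound 3 is also within the scatter, so the three numbers stand together without any one of them setting itself apart.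

Compound 4 `C[C@@H]1N[C@H](C(=O)N2CCC[C@H]2C#N)C[C@@H]1C(=O)N(C)C` is not yet measured. The change from compound 2 is dimethylamino in place of thiomorpholin-4-yl on a carbonyl carbon. For the measured compounds named here, the only measured step that bears on this carbonyl substituent is no change at the digits printed from compound 1 to compound 2 (within the scatter), a flat result when the amide group was exchanged; compound 3 carries a different amide on a different core and no step to it is available, so only its value is taken as a background. The expectation for compound 4 is a step of a number 2 percentage points lower from compound 2 to compound 4 (within the scatter), none beyond the scatter. Compound 4 is estimated at 90%, in the range 80% to 96%.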

Compound 4, a percentage reported as inhibition, in the whole organism at one dose (the size of the read-out at that dose, not a potency): 95%
Compound 4: the middle estimate sits 5 percentage points below what was measured; the measured number falls inside the stated range.
By their numbers in this assay, from the lowest: compounds 3, 1, 2 and 4 (each within the scatter of the next, the first and the last beyond it).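

In this assay, the three-heavy-atom dimethylamino stands in for the six-heavy-atom thiomorpholin-4-yl on this carbonyl carbon with a number 3 percentage points higher from compound 2 to compound 4 (within the scatter) as the result, so neither the ring nor the sulfur of thiomorpholin-4-yl is needed to hold this read-out at this dose. Trimming the other amide, with hydrogen in place of methyl on a saturated chain carbon bound to an amide-type nitrogen, gives a number 3 percentage points higher from compound 1 to compound 4 (within the scatter) and so also leaves the read-out within the scatter. Nothing measured here accounts for this flatness across the amide groups.

Going by these compounds, a carboxylic acid, or dibutylamino as a longer chain, on this carbonyl carbon remains open. So does whether these amides would separate from one another at a dose other than the single one given.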